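A few compounds are considered here, and "the series" means these few. Any claim that something is new, unique, unknown or untested is made for them only; others in the source may bear on it.

Measured so far: compound 1 `COc1ccc(-c2nc(SCC(=O)c3sc(-c4ccccc4)nc3C)nc(N)c2C#N)cc1`, compound 2 `COc1ccc(-c2nc(C)c(C(=O)CSc3nc(N)c(C#N)c(-c4ccc(OC)cc4)n3)s2)cc1` and compound 3 `Cc1nc(-c2ccc(Cl)cc2)sc1C(=O)CSc1nc(-c2ccccc2)c(C#N)c(=O)[nH]1`. In a functional assay on U-87MG ATCC cells for antiproliferative activity against U-87 MG (Homo sapiens), read by MTT assay, with a stated time of 48 h, tested at 10 uM (a higher number here means a weaker effect of the compound at the concentration tested, a lower number a stronger effect), compound 1 gives 60.8%, compound 2 gives 28.7% and compound 3 gives 83.1%. Compound 2 therefore stands lowest of the three, the strongest effect at the concentration tested, with both other values beyond the scatter from it. Compound 4 `COc1ccc(-c2nc(C)c(C(=O)CSc3nc(N)c(C#N)c(-c4ccc(Cl)cc4)n3)s2)cc1` differs from compound 2 in one place: chloro in place of methoxy on an aromatic carbon. Going by the values given here, the only measured step, a number 32.1 percentage points lower from compound 1 to compound 2 (beyond the scatter), concerns a methoxy at another aromatic carbon and a different swap, so it bears on this change only loosely. Compound 3 carries a 4-chlorophenyl on a different core, and its value alone shows that such compounds can give weak effects. A modest weakening is expected: a number 13.3 percentage points higher from compound 2 to compound 4 (beyond the scatter). Compound 4 is expected to give about 42%, between 22% and 66%.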

Compound 4, a percentage reported as activity, at one concentration (the size of the read-out at that concentration, not a potency): 44%
Estimate against measurement, compound 4: 2 percentage points below; the measured number falls inside the stated range.
By their numbers in this assay, from the lowest: compound 2; then compound 4; then compound 1; then compound 3.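

In this assay, going by these compounds alone, replacing 4-methoxyphenyl with 4-chlorophenyl gives a number 15.3 percentage points higher from compound 2 to compound 4 (beyond the scatter), the first reading of a change at this position. The methoxy can therefore give way to chloro at a modest cost here, and the step is smaller than the one seen for the methoxy added at the other aromatic carbon. No measurement at hand accounts for this step. Still open, on these data alone, is how an amine or a hydroxyl at this position would read, and whether the same swap gives a similar step with the other aromatic group changed.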